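The source may hold more compounds than are shown below. What is called first, only, known or untested is meant among the compounds shown, and "the series" means these compounds.

Compound 2 `O=C(/C=C\Nc1ccc2[nH]ccc2c1)c1nc(-c2ccc(C(F)(F)F)cc2)n2ccccc12` is tested in a functional assay on A549 cells (Homo sapiens) for cytotoxicity, read by MTT assay, with a stated time of 48 h (a lower number here means a stronger inhibitor, a higher number a weaker inhibitor), where compound 2 gives 5190 nM. Among the two numerical results in this assay it is the higher one, but only just: its nearest neighbour is compound 1 `COc1ccc(-c2nc(C(=O)/C=C\Nc3ccc4[nH]ccc4c3)c3ccccn23)cc1`, which gives 4800 nM, and the step of a 1.1-fold higher number from compound 1 to compound 2 (0.03 log units; within the scatter) stays within the scatter of repeated measurements. A third compound, compound 3 `COc1ccc(N/C=C\C(=O)c2nc(-c3ccc(F)cc3)n3ccccc23)cc1OC`, returns only a limit in this assay, > 30000 nM. This is the limit of > 30000 nM in this assay, at which 1 of the 3 values shown sits, so no number is available for it.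

Compound 4 `O=C(/C=C\Nc1cnc2ccccc2c1)c1nc(-c2ccc(C(F)(F)F)cc2)n2ccccc12` differs from compound 2 in one place: quinolin-3-yl in place of 1H-indol-5-yl on an amine nitrogen. Among the measured compounds shown here, the only measured single step, from compound 1 to compound 2, concerns the substituent on the aromatic ring at the other end of the molecule, not the group on the amine nitrogen, so it does not speak directly to this change. Compound 3 differs from compound 2 in two places at once and therefore gives no isolated reading either. For the measured compounds named here, with no matching step available, the expectation for compound 4 is a modest weakening, a 1.5-fold higher number from compound 2 to compound 4 (0.19 log units; within the scatter), carrying wide uncertainty. Compound 4 is therefore expected to give about 8000 nM in this assay, with a plausible range from 2500 nM to 30000 nM.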

Compound 4, half-maximal inhibitory concentration: > 30000 nM
Compound 4 was reported as a limit (the forecaster's own chance of this, stated with the estimate: 25%); middle value at least 3.7-fold (0.57 log units) away from the limit.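

Among the compounds shown here, the group on the amine nitrogen matters in this assay: whereas the one earlier single change, at the other end of the molecule, gave a 1.1-fold higher number from compound 1 to compound 2 (0.03 log units; within the scatter), quinolin-3-yl in place of 1H-indol-5-yl gives an at least 5.7-fold higher number from compound 2 to compound 4 (0.76 log units; beyond the scatter), the first single change here to lie beyond the scatter. So 1H-indol-5-yl at this position goes with a measurable number, while quinolin-3-yl under the same conditions yields only a limit, and the true size of the step remains unknown, so it can only be read as a minimum; compound 4 shares that limit with one other compound: the limit of > 30000 nM in this assay, at which 2 of the 4 values shown sit. The comparison also shows that the shared core and the trifluoromethyl group do not by themselves secure a measurable result, since compound 4 keeps both.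

This single swap changes the ring system and the hydrogen-bond donor and acceptor counts together, so the compounds shown cannot say which of these differences accounts for the step. On these data alone, how a plain phenyl or a 4-aminophenyl group on the same amine nitrogen would fare also stays open.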